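Propyl in Place of Cyclohexyl: Expected Toxicity Readout

A few compounds are considered here, and "the series" means these few. Any claim that something is new, unique, unknown or untested is made for them only; others in the source may bear on it.

Compound 1, `O=c1[nH]c(Nc2ccc(F)cc2F)nc2cc(Cl)ccc12`, in an ADME assay on Vero cells (Chlorocebus sabaeus) for cytotoxicity, read by WST assay (on this read-out lower numbers stand for higher toxicity in this test and higher numbers for lower toxicity in this test), gives > 25000 nM, which is a limit of the assay and not a number.
Compound 2, `O=c1[nH]c(NCC2CCCCC2)nc2cc(Cl)ccc12`, in this assay gives > 25000 nM, again a limit of the assay rather than a number.

Going by the values given here, compound 2 therefore stands at the upper edge of what this assay reports: the only information is the limit of > 25000 nM in this assay, at which 2 of the 2 values shown sit, so no ordering between compound 1 and compound 2 can be read from these two values, and neither can be called more or less toxic than the other.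

Compound 3, `CCCCNc1nc2cc(Cl)ccc2c(=O)[nH]1`, has not yet been tested. It differs from compound 2 by a single change: propyl in place of cyclohexyl on a saturated chain carbon bound to a nitrogen on an aromatic ring. Among the compounds with values here, no measured pair of compounds shows what such a change does in this assay, so there is no step to lean on. Given that compound 2 sits at the limit, the step from compound 2 to compound 3 is expected to be none beyond the scatter, with a step that the limit leaves unreadable from compound 2 to compound 3 as the estimate. Compound 3 is accordingly expected to give 30000 nM, within a range from 15000 nM to 60000 nM, most likely reported only as a limit.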

Compound 3, half-maximal cytotoxic concentration: > 25000 nM
Compound 3 gave a limit, no number; the forecaster's own chance of this, stated with the estimate: 85%; the middle value does not contradict the limit.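

Going by these compounds alone, no step from compound 2 to compound 3 can be read in this assay, because compound 2 and compound 3 both give only a limit of the assay, not a number: the limit of > 25000 nM in this assay, at which 3 of the 3 values shown sit.

Still open, as far as these compounds go, is whether propyl in place of cyclohexyl changes toxicity in this assay at all, and at what concentration compound 1, compound 2 or compound 3 would harm the cells.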